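The source may report more compounds than this note shows. Statements on the series, on what has been measured and on what is new or still open speak of the compounds shown alone.

Compound 1 `COc1cccc(OCCC(C)(C)C)c1C(=O)/C=C/c1ccc(O)cc1`: > 30000 nM
Compound 2 `CCCCCCOc1cccc(O)c1C(=O)/C=C/c1ccc(O)cc1`: > 30000 nM

In a functional assay on HCT-15 cells (Homo sapiens) for antiproliferative activity, read by sulforhodamine B assay (on this read-out lower numbers stand for stronger inhibition of growth and higher numbers for weaker inhibition of growth), compound 2 gives > 30000 nM, which is a limit and not a number. Compound 1 gives > 30000 nM, also a limit. Neither compound therefore has an exact value, and both sit at the limit of > 30000 nM in this assay, at which 2 of the 2 values shown sit.

Compound 3 `CC(C)(C)CCOc1cccc(O)c1C(=O)/C=C/c1ccc(O)cc1` has the same atoms as compound 2, joined differently: tert-butyl in place of butyl on a saturated chain carbon, two bonds along the chain from an oxygen on an aromatic ring.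

With no exact value as a starting point, no change beyond the usual scatter is expected in this assay, in either direction. The expected size of a number no higher from compound 2 to compound 3 (the limit leaves the size open) is therefore small. For compound 3 the estimate is 30000 nM, with an expected range of 12000 nM to 60000 nM.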

Compound 3, concentration for 50% growth inhibition: 3430 nM
Estimate against measurement, compound 3: 8.7-fold (0.94 log units) above; the whole stated range lies above it.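

In this assay, tert-butyl in place of butyl on the chain turns a limit into an exact value, with an at least 8.7-fold lower number from compound 2 to compound 3 (0.94 log units; beyond the scatter). With the branched chain kept, hydrogen in place of methyl on an oxygen on an aromatic ring gives an at least 8.7-fold lower number from compound 1 to compound 3 (0.94 log units; beyond the scatter), so both changes matter here. The true size of each step stays open, as compound 1 and compound 2 each stand at a limit: the limit of > 30000 nM in this assay, at which 2 of the 3 values shown sit.

Going by these compounds, it remains open whether a longer branched chain would give a lower number still, or whether an amine at the chain end would keep this activity.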